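A few compounds are considered here, and "the series" means these few. Any claim that something is new, unique, unknown or untested is made for them only; others in the source may bear on it.

Working notes on the series around the shared core. In a physicochemical assay for solubility, read by LC-MS, in phosphate buffer, with a stated time of 24 h, at pH 7.4 (a higher number here means a more soluble compound, a lower number a less soluble compound), compound 2 `CNC(=O)c1cc(-c2cnc(NCc3c(F)ccc4c3CCO4)c3cn[nH]c(=O)c23)n(C)n1` gives 7000 nM and compound 3 `CNC(=O)c1ncc(-c2cnc(NCc3c(F)ccc4c3CCO4)c3cn[nH]c(=O)c23)n1C` gives 5000 nM. These two compounds are close: a 1.4-fold lower number from compound 2 to compound 3 (0.15 log units; within the scatter). Compound 1 `Cc1ncccc1-c1cnc(NCc2c(F)ccc3c2CCO3)c2cn[nH]c(=O)c12` is reported only as a limit, < 2000 nM.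

The next step leads from compound 3 to compound 4 `Cc1nn(C)cc1-c1cnc(NCc2c(F)ccc3c2CCO3)c2cn[nH]c(=O)c12`: 1,3-dimethyl-1H-pyrazol-4-yl in place of 1-methyl-2-(methylcarbamoyl)-1H-imidazol-5-yl on an aromatic carbon. The methylcarbamoyl group is therefore lost, and compound 4, like compound 1, carries none.

Within the data shown here, two measured steps bear on this change: an at least 3.5-fold higher number from compound 1 to compound 2 (0.54 log units; beyond the scatter) and an at least 2.5-fold higher number from compound 1 to compound 3 (0.39 log units; beyond the scatter). On these data alone, both run towards a compound with the methylcarbamoyl group and both start from the limit, so their true size remains open. The step between the two compounds that carry the group, compound 2 and compound 3, offers little guidance, as it stays within the scatter. Among the measured compounds shown here, this reading rests on only three compounds, and none of them goes against it.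

A modest move to a lower number in this assay is therefore expected, and compound 4 may also be reported only as a limit. The estimated change is a 3.3-fold lower number from compound 3 to compound 4 (0.52 log units; beyond the scatter). Compound 4 is expected at 1500 nM, with an estimated range of 500 nM to 4000 nM.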

Compound 4, solubility: 9000 nM
The estimate for compound 4 lay 6.0-fold (0.78 log units) below the measured number; measured number above the stated range.
By their numbers in this assay, from the lowest: compounds 3, 2 and 4 (each within the scatter of the next). At a limit, below all of these: compound 1.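

In this assay, the methylcarbamoyl group turns out not to separate the compounds at this position on an aromatic carbon: 1,3-dimethyl-1H-pyrazol-4-yl carries none, and the steps read a 1.8-fold higher number from compound 3 to compound 4 (0.26 log units; within the scatter) and a 1.3-fold higher number from compound 2 to compound 4 (0.11 log units; within the scatter), so compound 4 cannot be told apart from the two compounds that carry the group. Compound 4 and compound 1 both lack the group, yet the step between them reads an at least 4.5-fold higher number from compound 1 to compound 4 (0.65 log units; beyond the scatter), so the difference seen earlier from compound 1 does not follow the methylcarbamoyl group in these four compounds. Compound 1 is reported as a limit and not as a number, which leaves the true size of all its steps open: the limit of < 2000 nM in this assay, at which 1 of the 4 values shown sits.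

No pair shown differs only by the methylcarbamoyl group on one and the same ring, so the contribution of that group alone cannot be read from these compounds. On these data alone, how an amine or a carboxylic acid on the five-membered ring at this position, or a longer chain in place of its methyl groups, would read in this assay also remains open.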